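This account rests on a few compounds, and the source may have more. Where it says the series, first, only, none or still open, it means among the compounds named here.

Measured in a physicochemical assay for solubility, with a stated time of 24 h, tested at 30 mg/mL; a higher number here means a more soluble compound, a lower number a less soluble compound:
Compound 1 `CC(=O)N1CC(CC(=O)NO)(NS(=O)(=O)c2ccc(OCc3cc(C)nc4ccccc34)cc2)C1`: 800000 nM
Compound 2 `CCc1cc(COc2ccc(S(=O)(=O)NC3(CC(=O)NO)CN(C(C)=O)C3)cc2)c2ccccc2n1`: 400000 nM

For the measured compounds named here, compound 1 stands level with compound 2, the only other measured compound, as their numbers lie within the usual scatter of each other. Compound 3 `Cc1cc(COc2ccc(S(=O)(=O)NC3(CC(=O)NO)CN(C(=O)CC(C)C)C3)cc2)c2ccccc2n1` keeps the core of compound 1 but carries isopropyl in place of hydrogen on a saturated chain carbon bound to a carbonyl carbon, so acetyl becomes isobutylcarbonyl. Going by the values given here, the one measured step, a 2.0-fold lower number from compound 1 to compound 2 (0.30 log units; within the scatter), is a loose guide, since it places methyl in place of hydrogen on a saturated chain carbon bound to an aromatic carbon. Among the compounds with values here, no measured compound shows a change at the new place. A modest move to a lower number, slightly beyond the scatter, is expected. The estimated step is a 3.2-fold lower number from compound 1 to compound 3 (0.51 log units; beyond the scatter). Compound 3 is expected at 250000 nM, with an estimated range of 70000 nM to 600000 nM.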

Compound 3, solubility: 900000 nM
For compound 3 the middle estimate is 3.6-fold (0.56 log units) below the measured one; the measured number lies above the stated range.
By their numbers in this assay, from the lowest: compounds 2, 1 and 3 (each within the scatter of the next, the first and the last beyond it).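

For the compounds shown here, compound 3 gives the first reading at a new place, the saturated chain carbon bound to a carbonyl carbon, where acetyl becomes isobutylcarbonyl. In this assay, isopropyl in place of hydrogen at this place gives a 1.1-fold higher number from compound 1 to compound 3 (0.05 log units; within the scatter) and so, despite the 3 added heavy atoms, the two compounds stand level within the usual scatter. Nothing at hand offers an explanation for this result.

A single step cannot show whether other groups at this place would also stay level, such as an amine, a carboxylic acid or a longer chain. It also leaves open whether isopropyl at this place would give the same result on the core of compound 2.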